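The compounds below may be only part of what the source reports. "The series", "measured", "known", "first", "only" and "open" are said of these compounds alone.

Compound 1 `COCC#Cc1cc(C(O)(C(F)(F)F)C(F)(F)F)cnc1N1CCN(S(=O)(=O)c2ccc(N)nc2)CC1`: 399 mL.min-1.g-1
Compound 2 `Nc1ccc(S(=O)(=O)N2CCN(c3ncc(C(O)(C(F)(F)F)C(F)(F)F)cc3-c3cccnc3)CC2)cn1`: 20 mL.min-1.g-1
Compound 3 `Nc1ccc(S(=O)(=O)N2CCN(c3ncc(C(O)(C(F)(F)F)C(F)(F)F)cc3-c3cnccc3F)CC2)cn1`: 22 mL.min-1.g-1

These numbers come from an ADME assay (liver) for metabolic stability, with Liver microsome (Rattus norvegicus) as the target, using microsomes and NADPH, with a stated time of 30 min, tested at 1 uM; a higher number here means faster removal of the compound, a lower number slower removal. The number for compound 3 stands close to its nearest neighbour, with a 1.1-fold higher number from compound 2 to compound 3 (0.04 log units; within the scatter), and far from the other end of the series, with an 18-fold lower number from compound 1 to compound 3 (1.26 log units; beyond the scatter). Compound 4 `Nc1ccc(S(=O)(=O)N2CCN(c3ncc(C(O)(C(F)(F)F)C(F)(F)F)cc3-c3ccc4scnc4c3)CC2)cn1` carries 1,3-benzothiazol-5-yl in place of 4-fluoropyridin-3-yl on an aromatic carbon. The large step of a 20-fold lower number from compound 1 to compound 2 (1.30 log units; beyond the scatter) shows that a swap at this place can move the number strongly, while the fluoro swap moved it only within the scatter. For the measured compounds named here, no measured step brings in 1,3-benzothiazol-5-yl, so a modest rise is expected, well short of that large step. The expected step is a 2.3-fold higher number from compound 3 to compound 4 (0.36 log units; beyond the scatter). For compound 4 the estimated value is 50 mL.min-1.g-1, with a range from 18 mL.min-1.g-1 to 150 mL.min-1.g-1.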

Compound 4, intrinsic clearance in microsomes: 147 mL.min-1.g-1
For compound 4 the middle estimate is 2.9-fold (0.47 log units) below the measured one, within the range that was stated.
By their numbers in this assay, from the lowest: compounds 2 and 3 (each within the scatter of the next); then compound 4; then compound 1.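

In this assay, this aromatic carbon, ortho to a large group, proves sensitive to the choice among ring groups and not only to the swap from chain to ring: 1,3-benzothiazol-5-yl gives a 6.7-fold higher number from compound 3 to compound 4 (0.82 log units; beyond the scatter) and a 7.4-fold higher number from compound 2 to compound 4 (0.87 log units; beyond the scatter). Even so, the fused ring does not return to the level of the 3-methoxyprop-1-yn-1-yl chain, with a 2.7-fold lower number from compound 1 to compound 4 (0.43 log units; beyond the scatter). Nothing available here explains this rise.

Still open, from the compounds shown here alone, is whether the fused second ring or the sulfur atom drives the rise. A plain phenyl ring or a 1,3-benzoxazol-5-yl group at this carbon could help separate the two.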